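The source may hold more compounds than are shown below. What is called first, only, known or untested is meant among the compounds shown, and "the series" means these compounds.

In a functional assay on KB cells (Homo sapiens) for antiproliferative activity, read by colorimetric assay and MTT assay (on this read-out lower numbers stand for stronger inhibition and higher numbers for weaker inhibition), compound 1 (`O=[N+]([O-])c1ccc(S(=O)(=O)Nc2cccc3c(Cl)c[nH]c23)cc1`) gives 14 ug/mL and compound 2 (`Nc1ccc(S(=O)(=O)Nc2cccc3c(Cl)c[nH]c23)cc1`) gives 10 ug/mL. Within the data shown here, the only measured step, a 1.4-fold lower number from compound 1 to compound 2 (0.15 log units; within the scatter), lies within the scatter, so these two compounds stand level on the numbers available. Compound 3 (`Cc1ccc(NS(=O)(=O)c2ccc(N)cc2)c2[nH]cc(Cl)c12`) differs from compound 2 by a single change: methyl in place of hydrogen on an aromatic carbon. This is methyl in place of hydrogen on an aromatic carbon, para to a large group. Among the measured compounds shown here, the one measured step swapped nitro for amino at a different place, so it bears on this change only indirectly, and no measured compound carries a methyl. The data therefore give no firm direction, and a shift within the scatter is the plainest expectation, with a slight lean towards a lower number. The expected change is a 1.4-fold lower number from compound 2 to compound 3 (0.15 log units; within the scatter). For compound 3 the estimated value is 7 ug/mL, with an expected range from 2 ug/mL to 25 ug/mL.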

Compound 3, half-maximal inhibitory concentration: 16 ug/mL
Compound 3: middle estimate off by 2.3-fold (0.36 log units), on the low side; the measured number falls inside the stated range.
By their numbers in this assay, from the lowest: compounds 2, 1 and 3 (each within the scatter of the next).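

In this assay, among these compounds, methyl in place of hydrogen on an aromatic carbon, para to a large group, gives a 1.6-fold higher number from compound 2 to compound 3 (0.20 log units; within the scatter) and so provides the first reading at this position. The earlier pair spoke only to amino in place of nitro at a different place, whereas this step shows that a methyl here leaves compound 3 level with compound 2 on this read-out. Nothing available bears on the reason for this result.

On these data alone, whether a methoxy, an amine or a carboxylic acid on this same carbon would also stay within the scatter remains open, as does the effect of a longer chain such as ethyl. As far as these compounds go, it is also open whether a methyl here would behave the same way with nitro in place of amino, as in compound 1.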